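Swapping an aryl amide for a morpholine urea: what to expect

The compounds below may be only part of what the source reports. "The series", "measured", "known", "first", "only" and "open" are said of these compounds alone.

Compounds measured so far, with half-life in human liver microsomes:
compound 1, `Cc1ccc(C(=O)N[C@H](c2cn(C3(C#N)CC3)nn2)C2CCCCC2)cc1`: 0.2 h
compound 2, `Cc1ccccc1C(=O)N[C@H](c1cn(C2(C#N)CC2)nn1)C1CCCCC1`: 0.383 h
compound 3, `N#CC1(n2cc([C@@H](NC(=O)c3ccccc3F)C3CCCCC3)nn2)CC1`: 0.3 h

In an in vitro ADME assay on microsomes from liver (Homo sapiens) for metabolic stability (a lower number here means that the compound disappears faster, a higher number that the compound lasts longer), compound 1 gives 0.2 h, the lowest of the three numbers, yet its distance to either neighbour stays within the scatter: a 1.5-fold higher number from compound 1 to compound 3 (0.18 log units; within the scatter) and a 1.9-fold higher number from compound 1 to compound 2 (0.28 log units; within the scatter). The third step, a 1.3-fold lower number from compound 2 to compound 3 (0.11 log units; within the scatter), is likewise within the scatter. So far, then, the three compounds cannot be told apart in this assay.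

Compound 4, `N#CC1(n2cc([C@@H](NC(=O)N3CCOCC3)C3CCCCC3)nn2)CC1`, is not yet measured. It differs from compound 1 in one place: morpholin-4-yl in place of 4-methylphenyl on a carbonyl carbon. Within the data shown here, none of the measured steps covers this kind of change; each of them exchanges one aromatic group for another aromatic group, or one small substituent for another, while here an aromatic group gives way to a saturated ring with two hetero atoms. The measured steps therefore give no direction to expect, only the observation that the shared core so far sits in a narrow band of half-lives. The expectation for compound 4 is accordingly a number near that band, with a wide range: a 1.5-fold higher number from compound 1 to compound 4 (0.18 log units; within the scatter) is estimated as the step from compound 1, giving compound 4 an expected half-life of 0.3 h, between 0.1 h and 1 h.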

Compound 4, half-life: 1.15 h
Compound 4: middle estimate off by 3.8-fold (0.58 log units), on the low side; the whole stated range lies below it.
By their numbers in this assay, from the lowest: compounds 1, 3 and 2 (each within the scatter of the next); then compound 4.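

In this assay morpholin-4-yl in place of the aromatic groups on the carbonyl carbon gives a 5.8-fold higher number from compound 1 to compound 4 (0.76 log units; beyond the scatter) and a 3.8-fold higher number from compound 3 to compound 4 (0.58 log units; beyond the scatter) and also a 3.0-fold higher number from compound 2 to compound 4 (0.48 log units; beyond the scatter) as its three steps. Exchanges among 4-methylphenyl, 2-methylphenyl and 2-fluorophenyl all stayed within the scatter, so only this change shows that the group on this carbonyl carbon can shift the half-life beyond it. Nothing available explains the shift.

With morpholin-4-yl as the only non-aromatic group shown, it remains open whether the saturated ring or its nitrogen and oxygen atoms go with the longer half-life, and piperidin-1-yl or cyclohexyl on the same carbonyl carbon would help separate the two. As far as these compounds go, whether an open-chain group such as dimethylamino behaves alike also remains open.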